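The compounds below may be only part of what the source reports. "The series", "measured", "known", "first", "only" and "open" are said of these compounds alone.

Going by the values given here, compound 1 `O=C(Nc1ccc(Oc2ccnc3[nH]ccc23)cc1)c1cc2cccnc2n(-c2ccccc2)c1=O` gives 380 nM in a functional assay on NCI-H460 cells (Homo sapiens) for antiproliferative activity, read by MTT assay, with a stated time of 72 h (a lower number here means a stronger inhibitor, a higher number a weaker inhibitor), and compound 1 stands highest of the two numbers so far in this assay. Its nearest neighbour is compound 2 `O=C(Nc1ccc(Oc2ccnc3[nH]ccc23)cc1)c1cc2cccnc2n(-c2ccc(Cl)cc2)c1=O`, which gives 290 nM in this assay, and the step of a 1.3-fold lower number from compound 1 to compound 2 (0.12 log units; within the scatter) lies within the scatter. Compound 3 `O=C(Nc1ccc(Oc2ccnc3[nH]ccc23)cc1)c1cc2cccnc2n(-c2ccc(Br)cc2F)c1=O` gives "not determined" (no result reported) in this assay, that is, no result reported.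

Compound 4 `O=C(Nc1ccc(Oc2ccnc3[nH]ccc23)c(F)c1)c1cc2cccnc2n(-c2ccccc2)c1=O` differs from compound 1 by fluoro in place of hydrogen on an aromatic carbon. Among the compounds with values here, the only measured step that bears on it is a 1.3-fold lower number from compound 1 to compound 2 (0.12 log units; within the scatter), a halogen added to a different part of the structure, and it was within the scatter. A step of no more than the scatter in this assay is therefore expected, in no particular direction, written as a 1.1-fold lower number from compound 1 to compound 4 (0.04 log units; within the scatter). Compound 4 is thus estimated to give 350 nM, within a range from 150 nM to 800 nM.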

Compound 4, half-maximal inhibitory concentration: 180 nM
Compound 4: the middle estimate sits 1.9-fold (0.29 log units) above what was measured; measured number inside the range.
By their numbers in this assay, from the lowest: compounds 4, 2 and 1 (each within the scatter of the next, the first and the last beyond it).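

In this assay, fluoro on this aromatic carbon, ortho to one large group and meta to another, gives a 2.1-fold lower number from compound 1 to compound 4 (0.32 log units; beyond the scatter) and so is a modest change. Unlike the chloro step on the other part of the structure, a 1.3-fold lower number from compound 1 to compound 2 (0.12 log units; within the scatter), this one passes the scatter, which shows that a single added atom at this place can move the number measurably. Nothing measured here explains the step.

Going by these compounds, whether chloro, methoxy or an amine at this same place would move the number further remains open. So does whether fluoro on another carbon of this ring would act in the same way.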